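From 2-chlorophenyl to 2,4,5-trichlorophenyl in compound 3

A few compounds are considered here, and "the series" means these few. Any claim that something is new, unique, unknown or untested is made for them only; others in the source may bear on it.

Results so far in a functional assay on RT-112 cells (Homo sapiens) for antiproliferative activity, read by MTT assay, with a stated time of 72 h (a higher number here means a weaker inhibitor of growth, a lower number a stronger inhibitor of growth), are these:

Compound 1 `COc1cc(NC(=O)Nc2cccc3c(Nc4cc(OC)cc(OC)c4)ncnc23)cc(OC)c1` gives 366 nM
Compound 2 `COc1cc(Nc2ncnc3c(NC(=O)Nc4cccc(Oc5ccccc5)c4)cccc23)cc(OC)c1` gives 14000 nM
Compound 3 `COc1cc(Nc2ncnc3c(NC(=O)Nc4ccccc4Cl)cccc23)cc(OC)c1` gives 356 nM

Compound 3 and compound 1 share the low end of these numbers and cannot be told apart. Among the measured compounds shown here, the one measured step between them is a 1.0-fold lower number from compound 1 to compound 3 (0.01 log units; within the scatter) and it comes from 2-chlorophenyl in place of 3,5-dimethoxyphenyl on an amide-type nitrogen. In this assay compound 2 stands far higher at 14000 nM so the group on that nitrogen is not always a neutral choice, although compound 1 and compound 3 show that a swap there can leave the number unmoved.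

The next compound is compound 4 `COc1cc(Nc2ncnc3c(NC(=O)Nc4cc(Cl)c(Cl)cc4Cl)cccc23)cc(OC)c1` with 2,4,5-trichlorophenyl in place of 2-chlorophenyl on an amide-type nitrogen. For the measured compounds named here, the change counts as 2,4,5-trichlorophenyl in place of 2-chlorophenyl on an amide-type nitrogen and no measured step tests it directly. The step of a 1.0-fold lower number from compound 1 to compound 3 (0.01 log units; within the scatter) argues for little movement, while compound 2 at 14000 nM warns that the number could rise, so a modest rise in this assay is expected. The expected change is a 1.7-fold higher number from compound 3 to compound 4 (0.23 log units; within the scatter) and this is only an estimate. Compound 4 is expected near 600 nM with an estimated range from 170 nM to 3000 nM until a measurement is available.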

Compound 4, concentration for 50% growth inhibition: 4890 nM
For compound 4 the middle estimate is 8.2-fold (0.91 log units) below the measured one; the whole stated range lies below it.
By their numbers in this assay, from the lowest: compounds 3 and 1 (each within the scatter of the next); then compound 4; then compound 2.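

In this assay the swap of 2-chlorophenyl for 2,4,5-trichlorophenyl on the amide-type nitrogen gives a 14-fold higher number from compound 3 to compound 4 (1.14 log units; beyond the scatter), so adding chlorine to a ring that already carries it is far from a neutral change at this position. The comparison with the 3,5-dimethoxyphenyl group points the same way, with a 13-fold higher number from compound 1 to compound 4 (1.13 log units; beyond the scatter), which shows that the match between compound 1 and compound 3 does not extend to every substituted phenyl ring placed here: among the compounds shown, the two smaller-numbered groups stand apart from 2,4,5-trichlorophenyl. No measurement is available that would account for this rise.

The compounds shown do not reveal whether the rise comes from one particular added chlorine or needs all of them together, a question that a dichlorophenyl group would begin to separate. They also leave open how an unsubstituted phenyl ring, or a phenyl ring bearing an amine or a carboxylic acid, would behave on the same nitrogen.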